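From furanylmethyl to propanoyl on the ring nitrogen

The source may report more compounds than this note shows. Statements on the series, on what has been measured and on what is new or still open speak of the compounds shown alone.

Compound 3 `CCCCNc1nc(N)nc2c1CN(Cc1ccco1)CC2` gives 0.08 uM in an assay on HEK293 cells for agonist activity at Toll-like receptor 8 (Homo sapiens), read by a luciferase reporter, with a stated time of 6 h (a higher number here means that more compound is needed for the effect, a lower number that less compound is needed), the second highest of three numbers; its nearest neighbour is compound 2 `CCCCNc1nc(N)nc2c1CN(Cc1ccccn1)CC2` with 0.07 uM, a gap within the scatter, and its furthest is compound 1 `CCCCNc1nc(N)nc2c1CN(S(C)(=O)=O)CC2` with 9.9 uM. Compound 4 `CCCCNc1nc(N)nc2c1CN(C(=O)CC)CC2` differs from compound 3 by propanoyl in place of (furan-2-yl)methyl on an amine nitrogen in a ring. Within the data shown here, the steps that bear on this are a 140-fold lower number from compound 1 to compound 2 (2.15 log units; beyond the scatter) and a 120-fold lower number from compound 1 to compound 3 (2.09 log units; beyond the scatter), both large steps on the same ring nitrogen, while a 1.1-fold higher number from compound 2 to compound 3 (0.06 log units; within the scatter) shows the two measured substituents there give similar numbers. Propanoyl itself has not been measured, so the size is uncertain, but the loss of (furan-2-yl)methyl is expected to raise the number considerably. Compound 4 is therefore estimated at 3 uM (range 0.5 uM to 15 uM), a step of a 38-fold higher number from compound 3 to compound 4 (1.57 log units; beyond the scatter).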

Compound 4, minimum effective concentration: 0.4 uM
The estimate for compound 4 lay 7.5-fold (0.88 log units) above the measured number; measured number outside the range, below it.
By their numbers in this assay, from the lowest: compounds 2 and 3 (each within the scatter of the next); then compound 4; then compound 1.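

In this assay, among these compounds, propanoyl on the ring nitrogen falls at an intermediate level that the earlier compounds did not show: there is a 5.0-fold higher number from compound 3 to compound 4 (0.70 log units; beyond the scatter) and a 5.7-fold higher number from compound 2 to compound 4 (0.76 log units; beyond the scatter), yet also a 25-fold lower number from compound 1 to compound 4 (1.39 log units; beyond the scatter). The position therefore separates propanoyl both from the two ring-bearing methyl groups and from methylsulfonyl. Nothing available explains this order.

On these data alone, whether the gap to the ring-bearing groups follows from the carbonyl or from the missing ring stays open. So does where a plain ethyl, a benzyl or a longer acyl chain such as butanoyl on this nitrogen would fall.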